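This account rests on a few compounds, and the source may have more. Where it says the series, first, only, none or still open, it means among the compounds named here.

In a functional assay for activation of Alpha-1A adrenergic receptor (Homo sapiens), read by calcium flux (a lower number here means that less compound is needed, a higher number that more compound is needed for the effect), the measured compounds read as follows.
Compound 1, `Cc1cccnc1-c1ccccc1OCC1=NCCN1`, reaches only a limit of the assay, < 100000 nM (the limit of < 100000 nM in this assay, at which 1 of the 3 values shown sits).
Compound 2, `Cc1cccc(-c2ccccc2OCC2=NCCN2)n1`, gives 126 nM.
Compound 3, `c1ccc(-c2cnccn2)c(OCC2=NCCN2)c1`, gives 2.51 nM.

Among the two real numbers, compound 3 stands lowest, so it needs the least compound for the effect; the nearest number, that of compound 2, is much higher, a gap well beyond the usual scatter of repeated measurements. The third value is a limit only and cannot be placed in that order.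

Compound 4, `c1c[nH]c(-c2ccccc2OCC2=NCCN2)c1`, differs from compound 3 in one place: 1H-pyrrol-2-yl in place of pyrazin-2-yl on an aromatic carbon. For the measured compounds named here, no step between measured compounds matches this change, so there is nothing measured to lean on. A moderate rise in the number is expected, one that may reach somewhat beyond the scatter but should stay far from the value of compound 2. Compound 4 is estimated at about 8 nM in this assay, within a range from 1.2 nM to 60 nM. The expected step is a 3.2-fold higher number from compound 3 to compound 4 (0.50 log units; beyond the scatter).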

Compound 4, half-maximal effective concentration: 1.26 nM
Compound 4: the middle estimate sits 6.3-fold (0.80 log units) above what was measured; the range from low to high includes it.
By their numbers in this assay, from the lowest: compounds 4 and 3 (each within the scatter of the next); then compound 2.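

Replacing pyrazin-2-yl with 1H-pyrrol-2-yl on this aromatic carbon, ortho to a group of 7 heavy atoms, gives a 2.0-fold lower number from compound 3 to compound 4 (0.30 log units; within the scatter) in this assay. Compound 4 is the first compound shown with a five-membered aromatic ring at this place, and the first whose ring there carries a hydrogen-bond donor, yet the two values cannot be told apart, so this position accepts that change of ring size and hydrogen-bonding count without a measurable shift in this assay. Nothing measured here explains why the two groups perform alike.

For the compounds shown here, with only this one pair, it remains open whether the hydrogen on the pyrrole nitrogen matters at all, which a furan or thiophene ring at the same place could test. From the compounds shown here alone, how a non-ring group such as an amine or a carboxylic acid would fare there also remains unknown.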